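A few compounds are considered here, and "the series" means these few. Any claim that something is new, unique, unknown or untested is made for them only; others in the source may bear on it.

Compound 1 `CC(=O)Oc1ccccc1C(=O)O[C@H]1CO[C@H]2[C@@H]1OC[C@H]2OC(=O)c1cccc(O)c1`: in an ADME assay on a cell-free system (plasma, Homo sapiens) for metabolic stability, with Plasma (Rattus norvegicus) as the target, read by HPLC, at pH 7.4 (a lower number here means that the compound disappears faster, a higher number that the compound lasts longer), compound 1 gives 0.015 h.
Compound 2 `CC(=O)Oc1ccccc1C(=O)O[C@H]1CO[C@H]2[C@@H]1OC[C@H]2OC(=O)C1CC1`: in this assay compound 2 gives 0.015 h.
Compound 3 `CC(=O)Oc1ccccc1C(=O)O[C@H]1CO[C@H]2[C@@H]1OC[C@H]2OC(=O)c1ccc(-c2ccccc2)cc1`: in this assay compound 3 gives > 0.333 h, which is a limit of the assay and not a number.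

Compound 3 therefore stands at the limit of > 0.333 h in this assay, at which 1 of the 3 values shown sits, and only this limit is known for it. What the numbers do show is that it lasts far longer than compound 1 and compound 2, which share one value between them, as no change at the digits printed from compound 1 to compound 2 (within the scatter) records for the cyclopropyl in place of 3-hydroxyphenyl on the carbonyl carbon.

The next compound is compound 4 `CC(=O)Oc1ccccc1C(=O)O[C@H]1CO[C@H]2[C@@H]1OC[C@H]2OC(=O)c1ccccc1CO[N+](=O)[O-]`, which differs from compound 3 in one place: 2-((nitrooxy)methyl)phenyl in place of 4-phenylphenyl on a carbonyl carbon.

Going by the values given here, two measured steps bear on this change, both ending at compound 3: an at least 22-fold higher number from compound 1 to compound 3 (1.34 log units; beyond the scatter) and an at least 22-fold higher number from compound 2 to compound 3 (1.34 log units; beyond the scatter). In each the 4-phenylphenyl group on the carbonyl carbon brought a large rise in this assay, and in each the group it replaced, whether an aromatic ring or a small carbocycle, sat at the same short half-life. Compound 4 removes that 4-phenylphenyl group in favour of another substituted phenyl, so a large fall in this assay is expected, in the direction of compound 1 and compound 2, though the exact size cannot be fixed because compound 3 is known only as a limit (the limit of > 0.333 h in this assay, at which 1 of the 3 values shown sits). The expected step is an at least 8.3-fold lower number from compound 3 to compound 4 (0.92 log units; beyond the scatter). For compound 4 the estimated half-life is 0.04 h, with a range from 0.012 h to 0.3 h.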

Compound 4, half-life: 0.0533 h
For compound 4 the middle estimate is 1.3-fold (0.12 log units) below the measured one; measured number inside the range.
By their numbers in this assay, from the lowest: compounds 1 and 2 (each within the scatter of the next); then compound 4. At a limit, above all of these: compound 3.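

In this assay, going by these compounds alone, the 2-((nitrooxy)methyl)phenyl group on the carbonyl carbon gives a level that the earlier compounds did not show, with a 3.6-fold higher number from compound 1 to compound 4 (0.55 log units; beyond the scatter) and a 3.6-fold higher number from compound 2 to compound 4 (0.55 log units; beyond the scatter) placing compound 4 clear of the short half-life shared by compound 1 and compound 2. The same change falls well short of the 4-phenylphenyl group, as an at least 6.2-fold lower number from compound 3 to compound 4 (0.79 log units; beyond the scatter) records, so this position is not limited to two extremes, and a group with one six-membered aromatic ring can stand above compound 1, which also has one such ring, while remaining under compound 3. The size of that fall is only a bound, for compound 3 is known solely as a limit of the assay: the limit of > 0.333 h in this assay, at which 1 of the 4 values shown sits.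

The compounds shown leave open whether the rise over compound 1 and compound 2 belongs to the nitrooxy part of the new group or to the substituted phenyl ring that carries it. As far as these compounds go, how a plain phenyl, a ring bearing an amine or a longer chain would fare on this carbonyl carbon also stays open.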